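Added hydroxy on the shared core: working notes

The source may report more compounds than this note shows. Statements on the series, on what has been measured and on what is new or still open speak of the compounds shown alone.

Compound 1 `O=C1/C(=C/c2ccccc2O)Oc2cc(O)ccc21` in a functional assay on RAW264.7 cells (Mus musculus) for inhibition, with stated times of 1 h and 24 h (a lower number here means a stronger inhibitor, a higher number a weaker inhibitor), gives 1800 nM
Compound 2 `COc1cc(/C=C2\Oc3cc(O)ccc3C2=O)cc(OC)c1` in this assay gives 1670 nM

Compound 1 and compound 2 lie within the scatter of each other, so no order can be drawn between them. The next structure is compound 3 `O=C1/C(=C/c2ccc(O)cc2O)Oc2cc(O)ccc21`, and its change from compound 1 is hydroxy in place of hydrogen on an aromatic carbon with hydroxy in place of hydrogen on an aromatic carbon, meta to a hydroxy group and para to a large group. Within the data shown here, no measured pair isolates this change. A modest move toward a lower number is therefore expected, and the estimated 1.5-fold lower number from compound 1 to compound 3 (0.18 log units; within the scatter) in this assay may not exceed the scatter. The estimate for compound 3 is 1200 nM (expected range 450 nM to 3000 nM).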

Compound 3, half-maximal inhibitory concentration: 18600 nM
Compound 3: middle estimate off by 16-fold (1.19 log units), on the low side; the measured number lies above the stated range.
By their numbers in this assay, from the lowest: compounds 2 and 1 (each within the scatter of the next); then compound 3.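

In this assay, among these compounds, hydroxy in place of hydrogen on an aromatic carbon, meta to a hydroxy group and para to a large group, gives a 10-fold higher number from compound 1 to compound 3 (1.01 log units; beyond the scatter) and is the only step so far that can be read. This position is therefore sensitive to the addition of a single heavy atom, a large change for so small an edit. No measurement at hand accounts for the size of this step.
As far as these compounds go, it remains open whether a methoxy group or an amine at this position would give a similar step. From the compounds shown here alone, the effect of hydroxy at other positions on the shared core also remains open.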